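Amide nitrogen substituent: aryl against benzyl across the series

The source may report more compounds than this note shows. Statements on the series, on what has been measured and on what is new or still open speak of the compounds shown alone.

Compound 3 `COc1ccc(CNC(=O)/C=C/c2coc3cc(OC)ccc3c2=O)cc1` gives the lowest number shown in a functional assay on Huh-7 cells (Homo sapiens) for inhibition, read by MTT assay, with a stated time of 48 h (on this read-out lower numbers stand for stronger inhibition and higher numbers for weaker inhibition), at 7570 nM. Compound 1 `COc1ccc2c(=O)c(/C=C/C(=O)NCc3ccc(F)cc3)coc2c1` gives 21000 nM in the same read-out, with a 2.8-fold lower number from compound 1 to compound 3 (0.44 log units; beyond the scatter). Compound 2 `COc1ccc(NC(=O)/C=C/c2coc3cc(OC)ccc3c2=O)cc1` returns only a limit, > 100000 nM. That entry is the limit of > 100000 nM in this assay, at which 1 of the 3 values shown sits. Compound 4 `COc1ccc2c(=O)c(/C=C/C(=O)Nc3ccccc3C)coc2c1` differs from compound 3 by 2-methylphenyl in place of 4-methoxybenzyl on an amide-type nitrogen. The measured steps that bear on an aryl in place of a benzyl group on this nitrogen are an at least 13-fold lower number from compound 2 to compound 3 (1.12 log units; beyond the scatter) and an at least 4.7-fold higher number from compound 1 to compound 2 (0.67 log units; beyond the scatter); both run in the same direction, toward a much higher number for the aryl amide. A large upward step is therefore expected, a 12-fold higher number from compound 3 to compound 4 (1.08 log units; beyond the scatter). Compound 4 is estimated at 90000 nM, with a range of 25000 nM to 300000 nM, and may well come back only as a limit.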

Compound 4, half-maximal inhibitory concentration: 26900 nM
For compound 4 the middle estimate is 3.3-fold (0.52 log units) above the measured one, and the stated range covers the measured number.
By their numbers in this assay, from the lowest: compound 3; then compounds 1 and 4 (each within the scatter of the next). At a limit, above all of these: compound 2.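

An aryl group on the amide-type nitrogen does not by itself push the number to the top of the range, as 2-methylphenyl gives an at least 3.7-fold lower number from compound 2 to compound 4 (0.57 log units; beyond the scatter). Compound 2 stands only as a limit: the limit of > 100000 nM in this assay, at which 1 of the 4 values shown sits. The benzyl against aryl contrast is thus less uniform than compound 2 suggested: 4-methoxybenzyl keeps an edge, with a 3.6-fold higher number from compound 3 to compound 4 (0.55 log units; beyond the scatter), yet 2-methylphenyl cannot be told apart from 4-fluorobenzyl, with a 1.3-fold higher number from compound 1 to compound 4 (0.11 log units; within the scatter).

Going by these compounds, whether the methyl or the methoxy group separates compound 4 from compound 2 stays open. On these data alone, how a plain phenyl, a longer chain or an amine on this nitrogen would read also stays open.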